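Thiophene sulfonamide in place of phenyl on the core

The compounds below may be only part of what the source reports. "The series", "measured", "known", "first", "only" and "open" are said of these compounds alone.

Among the compounds with values here, compound 1 `CS(=O)(=O)c1ccc(Cc2nnc3n2N=C(c2ccccc2)CS3)cc1` is the lower of the two numbers known so far; in a functional assay on RAW264.7 cells (Mus musculus) for cytotoxicity, read by MTT assay, with a stated time of 48 h, tested at 50 uM (on this read-out higher numbers stand for a stronger effect at the one concentration tested and lower numbers for a weaker effect), compound 1 gives 46.7%. Within the data shown here, compound 2 `CS(=O)(=O)c1ccc(Cc2nnc3n2N=C(c2ccc(-c4ccccc4)cc2)CS3)cc1` gives 67.9% in this assay, and the step of a number 21.2 percentage points higher from compound 1 to compound 2 (beyond the scatter) is the only measured step. Compound 3 `CS(=O)(=O)c1ccc(Cc2nnc3n2N=C(c2cc(Cl)sc2S(N)(=O)=O)CS3)cc1` differs from compound 1 by 5-chloro-2-sulfamoylthiophen-3-yl in place of phenyl on a carbon with a double bond to nitrogen. Among the measured compounds shown here, no measured step exchanges the aryl group itself, so the step to compound 2 bears only loosely on this replacement. Compound 3 is therefore expected to stay close, with a number 1.7 percentage points lower from compound 1 to compound 3 (within the scatter) estimated as a step within the scatter. Compound 3 is estimated at 45%, range 25% to 65%.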

Compound 3, a percentage reported as activity, at one concentration (the size of the read-out at that concentration, not a potency): 27.5%
Beside the measured number, compound 3's estimate is 17.5 percentage points above it; the measured number falls inside the stated range.
By their numbers in this assay, from the lowest: compound 3; then compound 1; then compound 2.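

The aryl group on the carbon with a double bond to nitrogen matters in its own right: in this assay there is a number 19.2 percentage points lower from compound 1 to compound 3 (beyond the scatter). The earlier step, a number 21.2 percentage points higher from compound 1 to compound 2 (beyond the scatter), added phenyl to the aryl group and went upward, so this position allows movement in both directions across the listed compounds. No available evidence accounts for the fall.

The new group changes the ring and adds chlorine and sulfamoyl together, so the step cannot be assigned to any one of them. As far as these compounds go, whether plain thiophen-3-yl or an amine-bearing phenyl would stay near compound 1 remains open.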